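From Compound 2 to Compound 4: An Expected Small Step

The compounds below may be only part of what the source reports. "The series", "measured", "known", "first", "only" and "open" are said of these compounds alone.

Of the compounds shown here, three sharing one core have been tested in a functional assay on 3T3-L1 cells (Mus musculus) for inhibition, with a stated time of 20 min, tested at 20 uM; a higher number here means more inhibition at the concentration tested (going by the name of the read-out), a lower number less inhibition. Compound 1 `Cc1ccc(S(=O)(=O)N(Cc2cn(Cc3ccc(F)cc3)nn2)Cc2c(-c3ccccc3)c3ccccc3n2S(=O)(=O)c2ccc(C)cc2)cc1` gives -7.6%. Compound 2 `COc1ccc(Cn2cc(CN(Cc3cn(S(=O)(=O)c4ccc(C)cc4)c4ccccc34)S(=O)(=O)c3ccc(C)cc3)nn2)c(OC)c1` gives 7.6%. Compound 3 `Cc1ccc(S(=O)(=O)N(Cc2cn(Cc3cc(F)ccc3F)nn2)Cc2cn(S(=O)(=O)c3ccccc3)c3ccccc23)cc1` gives -6.5%. Compound 2 stands highest of the three numbers; its nearest neighbour is compound 3, whose number lies lower by a margin beyond the scatter, and the furthest is compound 1, lower by a margin also beyond the scatter. For the measured compounds named here, no pair of these measured compounds differs in only one place, so no single step within the measured set can be read off directly.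

Compound 4 `Cc1ccc(S(=O)(=O)N(Cc2cn(Cc3ccc(F)cc3F)nn2)Cc2cn(S(=O)(=O)c3ccc(C)cc3)c3ccccc23)cc1` has not yet been measured in this assay. It is obtained from compound 2 by the change (2,4-difluorophenyl in place of 2,4-dimethoxyphenyl on a saturated chain carbon bound to an aromatic nitrogen). The closest measured analogue of compound 4 in structure is compound 3, which gives -6.5%, and all three measured numbers sit close to zero at the tested concentration. The account therefore expects a step from compound 2 to compound 4 of a number 7.6 percentage points lower from compound 2 to compound 4 (within the scatter), a drift downward that remains within the usual scatter. Compound 4 is accordingly estimated at 0%, in a range from -15% to 15%.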

Compound 4, a percentage reported as inhibition, at one concentration (the size of the read-out at that concentration, not a potency): 12.3%
Beside the measured number, compound 4's estimate is 12.3 percentage points below it; the range from low to high includes it.
By their numbers in this assay, from the lowest: compounds 1 and 3 (each within the scatter of the next); then compounds 2 and 4 (each within the scatter of the next).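

For the compounds shown here, replacing 2,4-dimethoxybenzyl with 2,4-difluorobenzyl gives the first comparison in this assay that isolates a single place, on a saturated chain carbon bound to an aromatic nitrogen, and the step reads a number 4.7 percentage points higher from compound 2 to compound 4 (within the scatter). At this position, then, the read-out does not separate the two groups, even though the group that leaves carries 2 hydrogen-bond acceptors and the one that enters carries 0, while the six-membered aromatic ring of carbon stays in place. No accompanying measurement bears on why the two groups read alike.

Going by these compounds alone, this single pair tests only two substituted benzyl groups on the shared core, so it cannot show whether the number stays level with other changes at the position in general or whether the same swap would read alike on a different core. Going by these compounds, it remains open whether an amine or a carboxylic acid on the aromatic ring, or a longer chain in place of the 2,4-difluorobenzyl group, would move the number beyond the scatter.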